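Swapping the aryl tail of compound 3 for a chain

The source may hold more compounds than are shown below. What is called first, only, known or untested is meant among the compounds shown, and "the series" means these compounds.

Compound 1 `COc1nc2ccccc2n1C(=O)NCCCCc1ccccc1`: 13.9 nM
Compound 2 `O=C(NCCCCc1ccccc1)N1C(=O)c2ccccc2C1=O`: 2.4 nM
Compound 3 `Cc1ccc(CNC(=O)n2c(N)nc3ccccc32)cc1`: 7 nM

In an assay on HEK293 cells for inhibition of acid ceramidase (Homo sapiens), read by fluorescence, with stated times of 30 min and 1 h (on this read-out lower numbers stand for stronger inhibition and higher numbers for weaker inhibition), compound 3 gives the second highest of these three numbers. Compound 1 lies nearest, and its number sits within the usual scatter of that of compound 3, so the two cannot be told apart. Compound 2 lies furthest, with a number lower than that of compound 3 by more than the scatter. Compound 4 `CCCCCCNC(=O)n1c(N)nc2ccccc21` has not been measured; it differs from compound 3 by pentyl in place of 4-methylphenyl on a saturated chain carbon bound to an amide-type nitrogen. Within the data shown here, no measured pair shows this exact change, so its size is open. In this assay the expected step is a 1.4-fold higher number from compound 3 to compound 4 (0.15 log units; within the scatter), modest and not beyond the scatter. For compound 4 the expected value is 10 nM, in the range 3 nM to 35 nM.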

Compound 4, half-maximal inhibitory concentration: 2.4 nM
Beside the measured number, compound 4's estimate is 4.2-fold (0.62 log units) above it; the whole stated range lies above it.
By their numbers in this assay, from the lowest: compounds 2 and 4 (each within the scatter of the next); then compounds 3 and 1 (each within the scatter of the next).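

In this assay, pentyl in place of 4-methylphenyl on a saturated chain carbon bound to an amide-type nitrogen gives a 2.9-fold lower number from compound 3 to compound 4 (0.46 log units; beyond the scatter). So on this core, the aromatic ring of the tail is not needed for strong inhibition, and a plain chain with no ring does better by more than the scatter. No measurement shown explains this gain.

Still open, going by these compounds, is how a shorter or longer chain would compare with pentyl. So is whether an amine or a carboxylic acid at the chain's end would keep this strength.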